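Swapping Furan-2-yl for Pyridin-3-yl in Compound 4

The source may report more compounds than this note shows. Statements on the series, on what has been measured and on what is new or still open speak of the compounds shown alone.

Three measured compounds share one core and differ only in where a hydroxyl sits on two attached phenyl rings. In a functional assay on T47D cells (Homo sapiens) for cytotoxicity, read by CCK-8 assay (on this read-out higher numbers stand for weaker inhibition and lower numbers for stronger inhibition), compound 1 `Oc1cccc(-c2cc(-c3ccco3)cc(-c3ccccc3O)n2)c1` gives 820 nM. Compound 2 `Oc1cccc(-c2cc(-c3ccco3)cc(-c3cccc(O)c3)n2)c1` gives 3520 nM in this assay, and compound 3 `Oc1ccc(-c2cc(-c3ccco3)cc(-c3cccc(O)c3)n2)cc1` gives 1280 nM. Compound 2 therefore stands at the highest number of the three, the weakest inhibition, with compound 3 its nearest neighbour and compound 1 the furthest, both gaps beyond the scatter.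

Compound 4 `Oc1cccc(-c2cc(-c3cccnc3)cc(-c3cccc(O)c3)n2)c1` is compound 2 with one change: pyridin-3-yl in place of furan-2-yl on an aromatic carbon. Among the measured compounds shown here, the three measured steps, a 4.3-fold higher number from compound 1 to compound 2 (0.63 log units; beyond the scatter), a 1.6-fold higher number from compound 1 to compound 3 (0.19 log units; within the scatter) and a 2.8-fold lower number from compound 2 to compound 3 (0.44 log units; beyond the scatter), each move a hydroxyl around a phenyl ring; none touches the furan-2-yl group, so no measured step bears directly on this change, and the data give no precedent for its size or direction. Without such a precedent, the step expected from compound 2 to compound 4 in this assay is a 1.0-fold lower number from compound 2 to compound 4 (0.00 log units; within the scatter), nothing beyond the scatter, though the uncertainty is wide. Compound 4 is therefore estimated at 3500 nM in this assay, with a likely range from 1200 nM to 10000 nM.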

Compound 4, half-maximal inhibitory concentration: > 50000 nM
Compound 4 was reported as a limit (the forecaster's own chance of this, stated with the estimate: 5%); at least 14-fold (1.15 log units) between middle value and limit.
By their numbers in this assay, from the lowest: compounds 1 and 3 (each within the scatter of the next); then compound 2. At a limit, above all of these: compound 4.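

In this assay, the group opposite the ring nitrogen turns out to matter more than any hydroxyl position seen so far: pyridin-3-yl in place of furan-2-yl gives an at least 14-fold higher number from compound 2 to compound 4 (1.15 log units; beyond the scatter), whereas the largest hydroxyl move gives a 4.3-fold higher number from compound 1 to compound 2 (0.63 log units; beyond the scatter). On these data alone, compound 4 is reported only as a limit, so the true size of its step stays unknown: the limit of > 50000 nM in this assay, at which 1 of the 4 values shown sits. The change looks small on paper, since both groups are single aromatic rings with 1 hetero atom, 0 hydrogen-bond donors, 1 hydrogen-bond acceptor and no net charge, so these counts do not separate a well-measured compound from one that reaches the limit.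

This single pair cannot tell whether the larger ring or the swap of oxygen for nitrogen goes with the weaker inhibition, and a thiophen-2-yl or plain phenyl group at this place would help to pull those two apart. As far as these compounds go, it also remains open whether the same swap would have a similar effect on the hydroxyl arrangements of compound 1 and compound 3.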